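A few compounds are considered here, and "the series" means these few. Any claim that something is new, unique, unknown or untested is made for them only; others in the source may bear on it.

Compound 3 `O=c1cc(CSC(=S)N2CCCCC2)oc2ccccc12` is the parent of this small set in a functional assay on MCF7 cells (Homo sapiens) for antiproliferative activity, read by MTT assay, with a stated time of 72 h; on this read-out lower numbers stand for stronger inhibition and higher numbers for weaker inhibition. In this assay compound 3 gives > 25000 nM, which is a limit of the assay and not a number. Compound 1 `O=c1cc(CSC(=S)N2CCCCC2)oc2cc(Cl)ccc12` carries a chloro group on the shared core, and in this assay compound 1 gives > 25000 nM, again a limit of the assay. Compound 2 `O=c1cc(CSC(=S)N2CCCC2)oc2ccccc12` holds a pyrrolidin-1-yl group on the thiocarbonyl carbon, and in this assay compound 2 gives 35800 nM. Two steps lead into compound 3: a step that the two limits leave unreadable from compound 1 to compound 3 and a step that the limit leaves unreadable from compound 2 to compound 3. Neither can be sized, since (the limit of > 25000 nM in this assay, at which 2 of the 3 values shown sit). Compound 4 `O=c1c(Cl)c(CSC(=S)N2CCCCC2)oc2ccccc12` differs from compound 3 by chloro in place of hydrogen on an aromatic carbon. Going by the values given here, no measured step puts a chloro group on that carbon; the one chloro step in the set ends in a limit at both ends and bears only loosely on it. With every value in the set either a limit or near that limit, no readable step offers a direction to take. The step from compound 3 to compound 4 is therefore expected to be small or itself unreadable, a step that the limit leaves unreadable from compound 3 to compound 4. Compound 4 is estimated at 30000 nM in this assay, with a range from 8000 nM to 110000 nM, and a good chance that only a limit is reported.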

Compound 4, half-maximal inhibitory concentration: 1000 nM
Estimate against measurement, compound 4: 30-fold (1.48 log units) above; measured number below the stated range.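

In this assay, going by these compounds alone, chloro in place of hydrogen on the aromatic carbon two atoms from the ring oxygen gives an at least 25-fold lower number from compound 3 to compound 4 (1.39 log units; beyond the scatter), the only step in this set that can be sized. This carbon of the six-membered aromatic ring with 1 oxygen is therefore a place on the shared core where a single heavy atom moves the read-out clearly towards stronger inhibition, and nothing shown gives the same result for a chloro group on any other carbon of the core. The earlier steps, including the one that places chloro on another carbon in compound 1, cannot be read and so gave no sign of this: the limit of > 25000 nM in this assay, at which 2 of the 4 values shown sit.

Whether the gain is particular to chloro stays open, as the compounds shown hold no other group on this carbon, such as bromo, methyl, an amine or a carboxylic acid. Also open, going by these compounds, is whether the same step carries over to the pyrrolidin-1-yl series of compound 2, or to a core that also bears the chloro group of compound 1, since only the piperidin-1-yl parent compound 3 provides a readable comparison here.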